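Replacing a pyridinyl with phenyl on a ring nitrogen

The source may hold more compounds than are shown below. What is called first, only, known or untested is meant among the compounds shown, and "the series" means these compounds.

Compound 1 `CN1CCN(c2nc(Nc3ccc(C#N)c(C(F)(F)F)c3)nc(Oc3ccnc4ccccc34)n2)CC1` and compound 2 `N#Cc1ccc(Nc2nc(Oc3ccnc4ccccc34)nc(N3CCN(c4ccccn4)CC3)n2)cc1C(F)(F)F` share one core and differ only in the group on an amine nitrogen in a ring. In a functional assay on DU-145 cells (Homo sapiens) for cytotoxicity, read by sulforhodamine B assay, with a stated time of 48 h (a lower number here means that less compound is tolerated, a higher number that more compound is tolerated), compound 1 reaches only the assay limit of > 100000 nM. In this assay, compound 2 likewise reaches only the assay limit of > 100000 nM. The step between them, a step that the two limits leave unreadable from compound 1 to compound 2, cannot be sized because of the limit of > 100000 nM in this assay, at which 2 of the 2 values shown sit. Compound 3 `N#Cc1ccc(Nc2nc(Oc3ccnc4ccccc34)nc(N3CCN(c4ccccc4)CC3)n2)cc1C(F)(F)F` takes the next step: phenyl in place of pyridin-2-yl on an amine nitrogen in a ring. Among the compounds with values here, the one measured step bears on this change only in that it, too, altered the group on that ring nitrogen, and it gave no readable size. With compound 2 standing at a limit, nothing points to a move into a measurable range, so the expected step from compound 2 to compound 3 is a number no higher from compound 2 to compound 3 (the limit leaves the size open), none beyond the scatter. Compound 3 is therefore estimated at 100000 nM, with a range from 30000 nM to 300000 nM, most likely again reported only as a limit.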

Compound 3, concentration lethal to 50% of the cells: > 100000 nM
Compound 3 ended at the assay's limit; the forecaster's own chance of this, stated with the estimate: 80%; the middle value lies on the limit itself.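

Within the data shown here, no step among compound 1, compound 2 and compound 3 can be read in this assay as a size, because each value is only a limit: (the limit of > 100000 nM in this assay, at which 3 of the 3 values shown sit). The compounds shown leave open whether any group on that ring nitrogen gives a value within the measurable range.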